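A few compounds are considered here, and "the series" means these few. Any claim that something is new, unique, unknown or untested is made for them only; others in the source may bear on it.

Compound 1 `C(=N/N(Cc1ccccc1)Cc1ccccc1)\c1ccccc1` is the only one of the three measured compounds to give a number: in an assay on liver (Sus scrofa) for inhibition of glucose-6-phosphatase catalytic subunit 1 (Homo sapiens), using microsomes (a lower number here means a stronger inhibitor, a higher number a weaker inhibitor), compound 1 gives 1500 nM. Compound 2 `COc1ccc2c(c1)CCC/C2=N\N(Cc1ccccc1)Cc1ccccc1` reaches only a limit, giving > 50000 nM in this assay. Compound 3 `COc1ccccc1/C=N/N(Cc1ccccc1)Cc1ccccc1` likewise reaches only a limit, giving > 100000 nM in this assay. Among the measured compounds shown here, the one measured step that leads to compound 3 is an at least 66-fold higher number from compound 1 to compound 3 (1.82 log units; beyond the scatter), and it ends at the limit of > 100000 nM in this assay, at which 1 of the 3 values shown sits. Compound 3 therefore stands at the weak end of what is shown, with no number of its own.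

Compound 4 `Oc1ccc(/C=N/N(Cc2ccccc2)Cc2ccccc2)cc1` differs from compound 3 by 4-hydroxyphenyl in place of 2-methoxyphenyl on a carbon with a double bond to nitrogen. For the measured compounds named here, no measured step shows this exact change, so the only guide is that the methoxy in place of hydrogen, in the step from compound 1 to compound 3, was accompanied by a loss of measurable inhibition. Removing that methoxy and placing a hydroxyl elsewhere may bring compound 4 back toward a measurable value, though how far is uncertain. The expected step is an at least 10-fold lower number from compound 3 to compound 4 (1.00 log units; beyond the scatter). For compound 4 the estimate is 10000 nM, within a range from 1500 nM to 100000 nM.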

Compound 4, half-maximal inhibitory concentration: 2400 nM
Compound 4: the middle estimate sits 4.2-fold (0.62 log units) above what was measured; the range from low to high includes it.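

The change from 2-methoxyphenyl to 4-hydroxyphenyl on the carbon with a double bond to nitrogen gives an at least 41-fold lower number from compound 3 to compound 4 (1.61 log units; beyond the scatter), so this position can carry a substituted aromatic ring and still give a measurable value in this assay. Adding a hydroxyl to this aromatic ring gives a 1.6-fold higher number from compound 1 to compound 4 (0.20 log units; within the scatter), so the hydroxyl leaves inhibition about where it stood in compound 1. An oxygen-bearing group on this ring therefore does not always remove measurable inhibition, although compound 3 goes against any wider rule.

The step from compound 3 to compound 4 changes both the group and its place on the ring, so the compounds shown cannot separate these two changes; 2-hydroxyphenyl and 4-methoxyphenyl would do so. On these data alone, how an amine or a carboxylic acid at that ring place would behave also stays open.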